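The source may report more compounds than this note shows. Statements on the series, on what has been measured and on what is new or still open speak of the compounds shown alone.

In an ADME assay on HepG2 cells (Homo sapiens) for cytotoxicity, read by trypan blue exclusion, with a stated time of 48 h, in the presence of a further agent that is not named here (a higher number here means that more compound is tolerated, a lower number that less compound is tolerated), three compounds sharing one core have been examined, each carrying a different group on the amide-type nitrogen. Compound 1 `COc1ccc2nc(C)cc(OCC(=O)Nc3ccccc3Cl)c2c1` reaches only a limit of the assay, > 140000 nM (the limit of > 140000 nM in this assay, at which 1 of the 3 values shown sits). Compound 2 `COc1ccc2nc(C)cc(OCC(=O)Nc3ccc(Cl)cc3)c2c1` gives 71100 nM, and compound 3 `COc1ccc2nc(C)cc(OCC(=O)Nc3ccc(C)cc3)c2c1` gives 41500 nM. Among the two true numbers, compound 3 holds the lowest, but the step between them is a 1.7-fold lower number from compound 2 to compound 3 (0.23 log units; within the scatter), so the two cannot be told apart with confidence. From compound 1 the change is an at least 3.3-fold lower number from compound 1 to compound 3 (0.52 log units; beyond the scatter), and from compound 1 to compound 2 it is an at least 1.9-fold lower number from compound 1 to compound 2 (0.29 log units; that floor lies within the scatter).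

Compound 4 `C#CCNC(=O)COc1cc(C)nc2ccc(OC)cc12` differs from compound 3 by a single change: propargyl in place of 4-methylphenyl on an amide-type nitrogen. Among the compounds with values here, none of the measured steps replaces a ring on this nitrogen with a chain, so they offer no direct guide; they show only that swapping one aromatic group for another moved this assay by no more than a modest amount. The expectation for compound 4 is therefore a step of a 1.4-fold higher number from compound 3 to compound 4 (0.16 log units; within the scatter), roughly within the spread already seen. Compound 4 is estimated to give 60000 nM in this assay, expected to fall between 20000 nM and 180000 nM.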

Compound 4, half-maximal cytotoxic concentration: > 176000 nM
Compound 4: no number, only a limit; the forecaster's own chance of this, stated with the estimate: 25%; middle value at least 2.9-fold (0.46 log units) away from the limit.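

In this assay, putting the propargyl chain on the amide-type nitrogen in place of an aromatic ring moves the reading towards more compound being tolerated, with an at least 4.2-fold higher number from compound 3 to compound 4 (0.62 log units; beyond the scatter) and an at least 2.4-fold higher number from compound 2 to compound 4 (0.39 log units; beyond the scatter) both standing beyond the usual scatter. Within the data shown here, the earlier compounds only swapped one aromatic ring for another, so this is the first sign that a group with no ring can sit at this position, and that it goes with a higher reading than the 4-methylphenyl and 4-chlorophenyl groups give; compound 1, which keeps a ring and still reaches a limit, goes against any simple rule that rings lower the reading. As far as these compounds go, compound 4 gives a limit and not a number, so its steps are floors and the full size of the change stays unknown: the limit of > 176000 nM in this assay, at which 1 of the 4 values shown sits.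

The step between compound 1 and compound 4 cannot be read, because compound 1 also gives only a limit: the limit of > 140000 nM in this assay, at which 1 of the 4 values shown sits. A propyl group on this nitrogen would separate the effect of the triple bond from the loss of the ring, and a longer chain or a chain ending in a carboxylic acid would show how far the trend extends.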